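An Acyl Group in Place of Cyclopropylmethyl

This account rests on a few compounds, and the source may have more. Where it says the series, first, only, none or still open, it means among the compounds named here.

Compound 1, `Fc1ccc(C(SCCNC2CCN(Cc3ccccc3)CC2)c2ccc(F)cc2)cc1`, gives 3.81 nM in an assay on membranes from Cortex for displacement of a labelled ligand from Sigma non-opioid intracellular receptor 1 (Cavia porcellus), read by scintillation counting, with a stated time of 120 min; on this read-out lower numbers stand for stronger inhibition and higher numbers for weaker inhibition. Compound 2, `OC(Cc1ccccc1)CN1CCC(NCCSC(c2ccc(F)cc2)c2ccc(F)cc2)CC1`, gives 309 nM. Compound 3, `Fc1ccc(C(SCCNC2CCN(CC3CC3)CC2)c2ccc(F)cc2)cc1`, gives 269 nM.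

Compound 3 holds the second highest of the three numbers: compound 2 sits within the scatter of it, while compound 1 lies far lower, as a 71-fold higher number from compound 1 to compound 3 (1.85 log units; beyond the scatter) shows. Compound 4 is `O=C(c1ccccc1F)N1CCC(NCCSC(c2ccc(F)cc2)c2ccc(F)cc2)CC1`; it differs from compound 3 by (2-fluorophenyl)carbonyl in place of cyclopropylmethyl on an amine nitrogen in a ring. Within the data shown here, no measured step introduces a carbonyl-bearing group on this nitrogen. The steps that touch this position, a 71-fold higher number from compound 1 to compound 3 (1.85 log units; beyond the scatter) and an 81-fold higher number from compound 1 to compound 2 (1.91 log units; beyond the scatter), show that the substituent there can move the number greatly, yet both start from compound 1, and compound 2 and compound 3 are alike. The expected step in this assay is therefore a modest rise or none beyond the scatter, a 1.9-fold higher number from compound 3 to compound 4 (0.27 log units; within the scatter). Compound 4 is estimated at 500 nM, within a range of 120 nM to 2000 nM.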

Compound 4, inhibition constant: 3.57 nM
The estimate for compound 4 lay 140-fold (2.15 log units) above the measured number; measured number outside the range, below it.
By their numbers in this assay, from the lowest: compounds 4 and 1 (each within the scatter of the next); then compounds 3 and 2 (each within the scatter of the next).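

In this assay the amine nitrogen in a ring takes a (2-fluorophenyl)carbonyl group with a large fall in the number, seen in a 75-fold lower number from compound 3 to compound 4 (1.88 log units; beyond the scatter) and in an 87-fold lower number from compound 2 to compound 4 (1.94 log units; beyond the scatter) as well, so low numbers here are not confined to benzyl. Against benzyl itself the exchange stays within the scatter, as a 1.1-fold lower number from compound 1 to compound 4 (0.03 log units; within the scatter) shows. No measurement offered here explains this result. The compounds shown do not separate the carbonyl from the aromatic ring; an acetyl group or a 2-fluorobenzyl group on the same nitrogen would speak to that.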